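Fluorine on the Pendant Phenyl of Compound 2

A few compounds are considered here, and "the series" means these few. Any claim that something is new, unique, unknown or untested is made for them only; others in the source may bear on it.

Compound 1 `O=C(Nc1nc2ccc(F)cc2s1)c1cn(-c2ccccc2)nc1-c1ccccc1`: 10200 nM
Compound 2 `O=C(Nc1nc2ccc(Cl)cc2s1)c1cn(-c2ccccc2)nc1-c1ccccc1`: 7670 nM
Compound 3 `Cc1ccc2nc(NC(=O)c3cn(-c4ccccc4)nc3-c3ccccc3)sc2c1`: 26500 nM

All three numbers come from a functional assay on A549 cells (Homo sapiens) for cytotoxicity, read by MTT assay, with a stated time of 72 h; on this read-out higher numbers stand for weaker inhibition and lower numbers for stronger inhibition. Compound 2 gives the lowest of the three, but the step of a 1.3-fold lower number from compound 1 to compound 2 (0.12 log units; within the scatter) lies within the scatter, so compound 1 and compound 2 cannot be set apart from each other. The steps of a 2.6-fold higher number from compound 1 to compound 3 (0.41 log units; beyond the scatter) and a 3.5-fold higher number from compound 2 to compound 3 (0.54 log units; beyond the scatter) are beyond the scatter and mark compound 3 as the weaker of the three in this assay.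

Compound 4 `O=C(Nc1nc2ccc(Cl)cc2s1)c1cn(-c2ccccc2)nc1-c1ccc(F)cc1` differs from compound 2 in one place: fluoro in place of hydrogen on an aromatic carbon. Within the data shown here, every measured step so far exchanges a group on the fused ring system of the shared core; none of them touches the phenyl ring that receives the new fluoro. Among the measured compounds shown here, there is thus no measured step that bears directly on this change, and the only anchor is the value of compound 2 in this assay. The step of a 1.0-fold lower number from compound 2 to compound 4 (0.01 log units; within the scatter) is therefore expected to be small, with no direction that can be told from the scatter. Compound 4 is estimated to give 7500 nM in this assay, with a range from 3000 nM to 19000 nM.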

Compound 4, half-maximal inhibitory concentration: 3870 nM
Compound 4: middle estimate off by 1.9-fold (0.29 log units), on the high side; the measured number falls inside the stated range.
By their numbers in this assay, from the lowest: compounds 4, 2 and 1 (each within the scatter of the next, the first and the last beyond it); then compound 3.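

Among these compounds, the step of a 2.0-fold lower number from compound 2 to compound 4 (0.30 log units; within the scatter) is the first measured change on a phenyl ring rather than on the fused ring system of the shared core, and in this assay it stays within the scatter, so the two compounds cannot be set apart. This position, on an aromatic carbon para to a large group, therefore accepts the change from phenyl to 4-fluorophenyl with no step beyond the scatter, which the earlier exchanges of fluoro, chloro and methyl on the fused ring system could not show. No measurement at hand offers an explanation for this result.

The compounds shown leave open whether a larger or differently built group at this position, such as methoxy, an amine or a carboxylic acid, would give a step beyond the scatter, since a single fluoro is the only group seen here in place of hydrogen. They also leave open whether fluoro on the other phenyl ring, or the same fluoro paired with the fluoro or methyl group on the fused ring system instead of chloro, would give a comparable step.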